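Thiophene acrylamide series: nitro to methoxy on the aryl ring

This account rests on a few compounds, and the source may have more. Where it says the series, first, only, none or still open, it means among the compounds named here.

Measured so far:
- compound 1 `C/C(=C\c1cc(-c2ccccc2)cs1)C(N)=O` — 12700 nM
- compound 2 `C/C(=C\c1cc(-c2ccc(F)cc2)cs1)C(N)=O` — 20800 nM
- compound 3 `C/C(=C\c1cc(-c2ccc([N+](=O)[O-])cc2)cs1)C(N)=O` — 2900 nM

In a functional assay on HeLa cells (Homo sapiens) for cytotoxicity, read by CCK-8 assay, with a stated time of 24 h (on this read-out higher numbers stand for weaker inhibition and lower numbers for stronger inhibition), compound 3 gives the lowest of the three numbers. Its distance from compound 1 is a 4.4-fold lower number from compound 1 to compound 3 (0.64 log units; beyond the scatter) and from compound 2 is a 7.2-fold lower number from compound 2 to compound 3 (0.86 log units; beyond the scatter); compound 1 and compound 2 themselves differ only by a 1.6-fold higher number from compound 1 to compound 2 (0.21 log units; within the scatter). The gain for the nitro group is therefore the one clear feature of the set.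

Compound 4 `COc1ccc(-c2csc(/C=C(\C)C(N)=O)c2)cc1` carries methoxy in place of nitro on an aromatic carbon. Within the data shown here, no measured compound holds a methoxy group, so the only guide is that both steps that put the nitro group in place of hydrogen or fluoro lowered the number, and removing it is expected to give some of that back. Among the measured compounds shown here, compound 4 is estimated at 10000 nM (range 4000 nM to 30000 nM), a step of a 3.4-fold higher number from compound 3 to compound 4 (0.54 log units; beyond the scatter), landing near compounds 1 and 2 but with wide uncertainty, since no step so far shows what a methoxy group does.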

Compound 4, half-maximal inhibitory concentration: > 50000 nM
Compound 4 gave a limit, no number (the forecaster's own chance of this, stated with the estimate: 10%); middle value at least 5.0-fold (0.69 log units) away from the limit.
By their numbers in this assay, from the lowest: compound 3; then compounds 1 and 2 (each within the scatter of the next). At a limit, above all of these: compound 4.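

In this assay, this position now reads in both directions from hydrogen: nitro lowered the number, whereas methoxy gives an at least 3.9-fold higher number from compound 1 to compound 4 (0.59 log units; beyond the scatter), and the comparison with fluoro gives an at least 2.4-fold higher number from compound 2 to compound 4 (0.38 log units; beyond the scatter). The exchange of nitro for methoxy is the widest gap in the set, an at least 17-fold higher number from compound 3 to compound 4 (1.23 log units; beyond the scatter), so the outcome here depends on which group sits at this position, not merely on whether hydrogen is replaced. All three steps rest on the limit of compound 4 and give minimum sizes only: the limit of > 50000 nM in this assay, at which 1 of the 4 values shown sits.

As far as these compounds go, it stays open whether the low number belongs to nitro alone or is shared by other groups here, such as a nitrile, a trifluoromethyl or an amine. From the compounds shown here alone, how far compound 4 lies past its limit also stays open.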